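Cyclopentyl for hexyl on sulfur: cytotoxicity outlook

The source may report more compounds than this note shows. Statements on the series, on what has been measured and on what is new or still open speak of the compounds shown alone.

Compound 1, `Nc1nc(NC2CCCCC2)c2ncn(/C=C3/CC3(CO)CO)c2n1`, in an ADME assay on BCBL1 cells (Homo sapiens) for cytotoxicity, with a stated time of 7 days (on this read-out lower numbers stand for higher toxicity in this test and higher numbers for lower toxicity in this test), compound 1 gives > 20000 nM, which is a limit of the assay rather than a number.
Compound 2, `CC(C)CNc1nc(N)nc2c1ncn2/C=C1/CC1(CO)CO`, gives > 20000 nM, again a limit.
Compound 3, `CCCCCCSc1nc(N)nc2c1ncn2/C=C1/CC1(CO)CO`, gives > 20000 nM, also a limit.

Compound 3 therefore stands at the limit, and so do the other two values: all sit at the limit of > 20000 nM in this assay, at which 3 of the 3 values shown sit. The change under study is cyclopentyl in place of hexyl on a sulfur, which turns compound 3 into compound 4, `Nc1nc(SC2CCCC2)c2ncn(/C=C3/CC3(CO)CO)c2n1`. The steps that touch the group on the aromatic carbon, a step that the two limits leave unreadable from compound 1 to compound 3 and a step that the two limits leave unreadable from compound 2 to compound 3, are both unreadable, as is a step that the two limits leave unreadable from compound 1 to compound 2, since every value involved is only a limit. No direction and no size can be drawn from them. The expected step is a step that the limit leaves unreadable from compound 3 to compound 4, meaning no change that the assay could show. Compound 4 is estimated at 30000 nM, with a range from 10000 nM to 100000 nM, and the most likely outcome is that the assay again reports only a limit.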

Compound 4, half-maximal cytotoxic concentration: > 20000 nM
Compound 4: only a limit was reported; the forecaster's own chance of this, stated with the estimate: 85%; the middle value does not contradict the limit.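

No step can be read among compound 1, compound 2, compound 3 and compound 4, since each gives only a limit: the limit of > 20000 nM in this assay, at which 4 of the 4 values shown sit.

The compounds shown leave open whether any group on that aromatic carbon of the shared core would give an actual number in this assay.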